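Aryl substitution on the lactam analogue: compound 3 to compound 4

This account rests on a few compounds, and the source may have more. Where it says the series, first, only, none or still open, it means among the compounds named here.

Three compounds have numbers in a functional assay on HT-29 cells (Homo sapiens) for inhibition, read by sulforhodamine B assay, with a stated time of 48 h; on this read-out higher numbers stand for weaker inhibition of growth and lower numbers for stronger inhibition of growth. Within the data shown here, compound 1 `COc1cc(/C=C/C2CC=CC(=O)O2)cc(OC)c1` gives 8.2 uM, and compound 2 `COc1cc(/C=C/C2CC=CC(=O)O2)cc(OC)c1OC` gives 18.8 uM; the one step among them, a 2.3-fold higher number from compound 1 to compound 2 (0.36 log units; beyond the scatter), came from a methoxy in place of hydrogen on an aromatic carbon. Compound 3 `O=C1C=CCC(/C=C/c2ccccc2)N1`, built on a different core, stands at the weak end: in this assay compound 3 gives 1200 uM, a far higher number than either compound 1 or compound 2.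

Compound 4 `O=C1C=CCC(/C=C/c2ccccc2C(F)(F)F)N1` differs from compound 3 by trifluoromethyl in place of hydrogen on an aromatic carbon; the trifluoromethyl sits on the six-membered aromatic ring of carbon only, ortho to the group of nine heavy atoms. Among the measured compounds shown here, no measured step involves a trifluoromethyl, and the single step from compound 1 to compound 2 concerns another core and another group, so it carries little weight here. With nothing in the data pointing one way, the expected change for compound 4 is small, a 1.3-fold lower number from compound 3 to compound 4 (0.12 log units; within the scatter), lying within or near the usual scatter. Compound 4 is therefore estimated at 900 uM in this assay, with a range from 250 uM to 3000 uM; a reading that comes back only as a limit is a real possibility given where compound 3 stands.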

Compound 4, concentration for growth inhibition (reported as GI): 195 uM
For compound 4 the middle estimate is 4.6-fold (0.66 log units) above the measured one; measured number below the stated range.
By their numbers in this assay, from the lowest: compound 1; then compound 2; then compound 4; then compound 3.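

On the core of compound 3, the aromatic ring accepts a substituent at this place: trifluoromethyl, on an aromatic carbon ortho to a group of 9 heavy atoms, gives a 6.2-fold lower number from compound 3 to compound 4 (0.79 log units; beyond the scatter) in this assay. Among these compounds, this is the first measured step on this core, and the change lies beyond the usual scatter, though it is rated modest. It is also the first step shown in which adding a group to the aromatic ring lowers the number, since the only earlier step, a 2.3-fold higher number from compound 1 to compound 2 (0.36 log units; beyond the scatter), raised it, but that step has another core and another group and so sets no rule for this one. No available evidence bears on why trifluoromethyl has this effect at this place.

Still open, on these data alone, is whether the lower number belongs to trifluoromethyl itself or would also follow from a fluorine, a chlorine, a nitrile or an amine on the same aromatic carbon. Also open, as far as these compounds go, is whether trifluoromethyl on another carbon of the ring, or the methoxy groups of compound 1 on the core of compound 3, would move the number further.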